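The compounds below may be only part of what the source reports. "The series", "measured", "known", "first", "only" and "open" are said of these compounds alone.

Compound 1 `Nc1cc(Cc2ccn(-c3cccc(-c4ccccc4)c3)n2)c2nn[nH]c2n1` in an assay on cells for inhibition of thyroid peroxidase (Homo sapiens), with stated times of 10 min and 15 min (on this read-out higher numbers stand for weaker inhibition and lower numbers for stronger inhibition), gives 710 nM.
Compound 2 `Nc1cc(Cc2ccn(Cc3cccc(-c4ccccc4)c3)n2)c2nn[nH]c2n1` in this assay gives 1100 nM.

Of the two numbers measured in this assay, compound 2 has the higher one, yet its gap to compound 1 lies within the scatter, so the two compounds cannot be told apart. Compound 3 `Nc1cc(Cc2ccn(Cc3cccc(C4CCNCC4)c3)n2)c2nn[nH]c2n1` has not yet been measured. It differs from compound 2 by piperidin-4-yl in place of phenyl on an aromatic carbon. Going by the values given here, no measured pair shows such a change, so there is no basis for a directed expectation; the step of a 1.3-fold higher number from compound 2 to compound 3 (0.10 log units; within the scatter) is estimated to stay within the scatter, with wide uncertainty on both sides. Compound 3 is expected at 1400 nM, in the range 350 nM to 6000 nM.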

Compound 3, half-maximal inhibitory concentration: 21000 nM
Estimate against measurement, compound 3: 15-fold (1.18 log units) below; measured number above the stated range.
By their numbers in this assay, from the lowest: compounds 1 and 2 (each within the scatter of the next); then compound 3.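

In this assay, piperidin-4-yl in place of phenyl on the aromatic carbon gives a 19-fold higher number from compound 2 to compound 3 (1.28 log units; beyond the scatter). Going by these compounds alone, the earlier compounds both carried phenyl here, so this pair is the first to show that the number responds strongly to the group at this place. The change swaps an aromatic carbon ring for a non-aromatic ring with one hetero atom and adds a hydrogen-bond donor and acceptor, and nothing measured here accounts for the step. As far as these compounds go, whether the rise follows the lost aromatic ring or the ring nitrogen stays open; cyclohexyl or pyridinyl at this place would separate the two.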